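Ring amine replaces a propylamino chain at the amide carbon

The source may report more compounds than this note shows. Statements on the series, on what has been measured and on what is new or still open speak of the compounds shown alone.

The series is followed in a functional assay on MGC-803 cells (Homo sapiens) for cytotoxicity, read by MTT assay, with a stated time of 48 h; on this read-out higher numbers stand for weaker inhibition and lower numbers for stronger inhibition. Compound 1 `CC1=NN(C(=O)CN2CCCC2)C(c2ccccc2O)C1` gives 17900 nM, compound 2 `CC1=NN(C(=O)CN2CCN(C)CC2)C(c2ccccc2O)C1` gives 7850 nM, and compound 3 `CCCNCC(=O)N1N=C(c2cc3ccccc3oc2=O)CC1c1ccccc1` gives 4880 nM. Within the data shown here, compound 3 stands at the lowest of the three numbers, but its gap to compound 2 is within the scatter, so only its gap to compound 1 separates it; the one recorded step, a 2.3-fold lower number from compound 1 to compound 2 (0.36 log units; beyond the scatter), is modest. The unmeasured compound 4 `NC(=O)C1CCN(CC(=O)N2N=C(c3cc4ccccc4oc3=O)CC2c2ccccc2)CC1` differs from compound 3 as follows: 4-carbamoylpiperidin-1-yl in place of propylamino on a saturated chain carbon bound to a carbonyl carbon. The step from compound 1 to compound 2 is the only measured one at the same place, a saturated chain carbon bound to a carbonyl carbon, and it exchanged one amine for another while staying modest; here a chain amine, propylamino, is exchanged for a ring amine, 4-carbamoylpiperidin-1-yl, on a different core. Compound 4 is therefore expected to lie close to compound 3, with a step of a 1.4-fold lower number from compound 3 to compound 4 (0.14 log units; within the scatter) that need not exceed the scatter, and an estimated value of 3500 nM in this assay, between 1200 nM and 10000 nM.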

Compound 4, half-maximal inhibitory concentration: 21500 nM
Compound 4: middle estimate off by 6.1-fold (0.79 log units), on the low side; measured number above the stated range.
By their numbers in this assay, from the lowest: compounds 3 and 2 (each within the scatter of the next); then compounds 1 and 4 (each within the scatter of the next).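

In this assay, the place on a saturated chain carbon bound to a carbonyl carbon does not tolerate every amine alike on this core: 4-carbamoylpiperidin-1-yl in place of propylamino gives a 4.4-fold higher number from compound 3 to compound 4 (0.64 log units; beyond the scatter), a rise in the number. The earlier step at this place, a 2.3-fold lower number from compound 1 to compound 2 (0.36 log units; beyond the scatter), ran the opposite way between two ring amines on a different core, so a ring amine here does not by itself go with either a higher or a lower number. No measurement shown explains the weaker inhibition of compound 4.

From the compounds shown here alone, it remains open whether the ring or its carbamoyl group goes with the higher number, a question that plain piperidin-1-yl on this core would address. Whether a longer chain such as butylamino would hold the number of compound 3 is also unsettled.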